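A Benzoyl Ester in Place of a Methyl Ether

The compounds below may be only part of what the source reports. "The series", "measured", "known", "first", "only" and "open" are said of these compounds alone.

Compound 1 `CCC1(Cc2ccccc2)OS(=O)(=O)C=C1OC` was tested in an ADME assay on HEL cells (Homo sapiens) for cytotoxicity, with a stated time of 3 days; a lower number here means that less compound is tolerated, a higher number that more compound is tolerated. For compound 1 the read-out is only a limit of the assay, > 400000 nM. A related compound 2 `CCC1(Cc2ccccc2)OS(=O)(=O)C=C1OCc1ccc(Cl)c(Cl)c1` carries a 3,4-dichlorophenyl in place of hydrogen on a saturated chain carbon bound to an oxygen on an unsaturated carbon. In this assay compound 2 likewise returns only a limit, >= 20000 nM. Both readings being limits, the step that the two limits leave unreadable from compound 1 to compound 2 cannot be sized; the two values simply sit at the limit of > 400000 nM in this assay, at which 1 of the 2 values shown sits, and at the limit of >= 20000 nM in this assay, at which 1 of the 2 values shown sits.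

Compound 3 `CCC1(Cc2ccccc2)OS(=O)(=O)C=C1OC(=O)c1ccccc1` is not yet measured. It differs from compound 1 by benzoyl in place of methyl on an oxygen on an unsaturated carbon. Going by the values given here, no measured step bears on this change: the only step in hand lies at another position and is itself unreadable, so there is no basis for expecting a step in either direction beyond the scatter, and compound 1 itself stands only at a limit. Compound 3 is therefore estimated in this assay at 200000 nM, with a range from 40000 nM to 400000 nM. This estimate means an expected step of an at least 2.0-fold lower number from compound 1 to compound 3 (0.30 log units; that floor lies within the scatter).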

Compound 3, minimum cytotoxic concentration: > 400000 nM
Compound 3 was reported as a limit; the forecaster's own chance of this, stated with the estimate: 60%; middle value at least 2.0-fold (0.30 log units) away from the limit.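

Compound 1 and compound 3 both return only a limit in this assay, so no step between them can be read: the limit of > 400000 nM in this assay, at which 2 of the 3 values shown sit.

The compounds shown leave open whether benzoyl in place of methyl changes the concentration tolerated at all, and at what concentration compound 1 and compound 3 would begin to harm the cells.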